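The source may hold more compounds than are shown below. What is called first, only, known or untested is meant among the compounds shown, and "the series" means these compounds.

Three compounds have been measured in a functional assay on NCI-H460 cells (Homo sapiens) for inhibition, read by MTT assay, with a stated time of 24 h, tested at 10 ug/mL; on this read-out lower numbers stand for less inhibition of growth and higher numbers for more inhibition of growth at the one concentration tested:

Compound 1, `CC(=O)SCCC(CCCCC(=O)Nc1ccccc1Cl)SC(C)=O`: 11.4%
Compound 2, `CC(=O)SCCC(CCCCC(=O)Nc1cccc(Cl)c1)SC(C)=O`: 2.09%
Compound 3, `O=C(CCCCC(CCSC(=O)c1ccccc1)SC(=O)c1ccccc1)Nc1ccccc1Cl`: 12.1%

Compound 2 differs from compound 1 by 3-chlorophenyl in place of 2-chlorophenyl on an amide-type nitrogen, and this gave a number 9.3 percentage points lower from compound 1 to compound 2 (within the scatter). Compound 3 has a different core from compound 1; that difference between the two cores is not broken down here. Compound 4, `O=C(CCCCC(CCSC(=O)c1ccccc1)SC(=O)c1ccccc1)Nc1cccc(Cl)c1`, is not yet measured and differs from compound 3 by 3-chlorophenyl in place of 2-chlorophenyl on an amide-type nitrogen, the same change at the same kind of place as from compound 1 to compound 2. Because the earlier change gave a number 9.3 percentage points lower from compound 1 to compound 2 (within the scatter), compound 4 is expected to show a step of about a number 9.1 percentage points lower from compound 3 to compound 4 (within the scatter) in this assay. Compound 4 is therefore estimated at 3%, most likely between -8% and 14%.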

Compound 4, percent growth inhibition at one concentration: 9.12%
Compound 4: the middle estimate sits 6.1 percentage points below what was measured; low and high end bracket the measured number.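

In this assay, 3-chlorophenyl in place of 2-chlorophenyl on the amide-type nitrogen gave a number 3 percentage points lower from compound 3 to compound 4 (within the scatter). Set beside the same change on the other core, the two steps do not differ by more than ordinary scatter: the same change on two cores in this assay, a number 9.3 percentage points lower (within the scatter) from compound 1 to compound 2 and a number 3 percentage points lower (within the scatter) from compound 3 to compound 4, 6.3 percentage points apart, within the scatter of two such steps

This gives no sign that the core alters the change, but it does not prove that the two steps are equal, and with each step inside the scatter, it does not show that the change has a real effect on either core.

The compounds shown leave open whether other groups on the amide-type nitrogen, such as a carboxylic acid-bearing phenyl or a longer chain, would change growth inhibition beyond the scatter. Also open, as far as these compounds go, is what a free thiol would do in place of the acetyl and benzoyl thioesters.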